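The source may report more compounds than this note shows. Statements on the series, on what has been measured and on what is new or still open speak of the compounds shown alone.

Compound 1 `COc1ccc(-c2cn3ccnc3c(-c3ccc4ncn(C5CCCCC5)c4c3)n2)cc1` was tested in a functional assay on RXF 393 cells (Homo sapiens) for inhibition, read by sulforhodamine B assay, with a stated time of 48 h, tested at 10 uM (a higher number here means more inhibition at the concentration tested (going by the name of the read-out), a lower number less inhibition), where compound 1 gives -8.48%. Among the compounds with values here, that is the lowest of the two numbers measured so far; its only neighbour is compound 2 `O=Cc1ccc(-c2cn3ccnc3c(-c3ccc4ncn(C5CCCCC5)c4c3)n2)cc1`, which in this assay gives 25%. Within the data shown here, the one measured step, a number 33.5 percentage points higher from compound 1 to compound 2 (beyond the scatter), exchanges one substituent for a different one rather than keeping the same group.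

Compound 3 `COc1ccccc1-c1cn2ccnc2c(-c2ccc3ncn(C4CCCCC4)c3c2)n1` has not yet been measured. It differs from compound 1 by 2-methoxyphenyl in place of 4-methoxyphenyl on an aromatic carbon. Among the measured compounds shown here, no measured step bears directly on this change: the step from compound 1 to compound 2 replaced methoxy with formyl, whereas here the methoxy group is kept and the phenyl ring is carried as 2-methoxyphenyl instead of 4-methoxyphenyl, the two compounds having the same atoms joined differently. With nothing in the shown numbers to lean on, the expected step in this assay is none beyond the scatter, in no particular direction. The estimate for compound 3 is therefore -5%, with a range from -25% to 15%. The step this estimate implies, a number 3.5 percentage points higher from compound 1 to compound 3 (within the scatter), is expected to stay within the scatter.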

Compound 3, a percentage reported as inhibition, at one concentration (the size of the read-out at that concentration, not a potency): 0.95%
Beside the measured number, compound 3's estimate is 6 percentage points below it, and the stated range covers the measured number.
By their numbers in this assay, from the lowest: compounds 1 and 3 (each within the scatter of the next); then compound 2.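

Carrying the methoxy group as 2-methoxyphenyl rather than 4-methoxyphenyl gives a number 9.4 percentage points higher from compound 1 to compound 3 (within the scatter) in this assay, so this pair of compounds, with the same atoms joined differently, cannot be told apart at this position. The step of a number 24.1 percentage points lower from compound 2 to compound 3 (beyond the scatter) replaces 4-formylphenyl with 2-methoxyphenyl and places compound 3 with compound 1, leaving compound 2 as the only one of the three set apart from the others by more than the scatter; among these compounds, the two methoxyphenyl groups give the same picture, and only the 4-formylphenyl group stands out. Nothing measured here accounts for either step.

The compounds shown leave open whether the number of compound 2 is particular to the formyl group or would also appear with another group on the phenyl ring, such as a carboxylic acid, a hydroxymethyl or an amine. They also leave open whether the formyl group, moved around the phenyl ring as the methoxy group was here, would stay apart from the methoxyphenyl compounds.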